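Swapping the ring on the sulfonyl sulfur of compound 3

The source may hold more compounds than are shown below. What is called first, only, known or untested is meant among the compounds shown, and "the series" means these compounds.

Compound 3 `Cc1ccc(S(=O)(=O)Nc2ccc3oc(-c4ccccc4)nc3c2)cc1` shares its core with compound 1 `O=S(=O)(Nc1ccc2oc(-c3ccccc3)nc2c1)c1ccccc1O` and compound 2 `O=S(=O)(Nc1ccc2oc(-c3ccccc3)nc2c1)c1cccs1`. In an ADME assay on HEK293 cells (Homo sapiens) for cytotoxicity, read by resazurin assay, with a stated time of 48 h (a higher number here means that more compound is tolerated, a lower number that less compound is tolerated), compound 3 gives 75000 nM, compound 1 gives 33000 nM and compound 2 gives 97000 nM. Compound 3 therefore stands second highest of the three: its gap to compound 2 is within the scatter, while a 2.3-fold higher number from compound 1 to compound 3 (0.36 log units; beyond the scatter). Compound 4 `COc1ccc(Cl)cc1S(=O)(=O)Nc1ccc2oc(-c3ccccc3)nc2c1` differs from compound 3 by 5-chloro-2-methoxyphenyl in place of 4-methylphenyl on a sulfonyl sulfur. Within the data shown here, no measured step makes exactly this exchange; the nearest guides are a 2.3-fold higher number from compound 1 to compound 3 (0.36 log units; beyond the scatter), a 1.3-fold lower number from compound 2 to compound 3 (0.11 log units; within the scatter) and a 2.9-fold higher number from compound 1 to compound 2 (0.47 log units; beyond the scatter), all modest or within the scatter. A modest step is therefore expected, estimated as a 1.7-fold lower number from compound 3 to compound 4 (0.22 log units; within the scatter), leaning lower because compound 1 gives 33000 nM. Compound 4 is expected to give about 45000 nM, within a range from 15000 nM to 110000 nM.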

Compound 4, half-maximal cytotoxic concentration: 74000 nM
Estimate against measurement, compound 4: 1.6-fold (0.22 log units) below, and the stated range covers the measured number.
By their numbers in this assay, from the lowest: compound 1; then compounds 4, 3 and 2 (each within the scatter of the next).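

In this assay there is a 1.0-fold lower number from compound 3 to compound 4 (0.01 log units; within the scatter) and a 1.3-fold lower number from compound 2 to compound 4 (0.12 log units; within the scatter) even though 5-chloro-2-methoxyphenyl carries more heavy atoms than 4-methylphenyl and a hydrogen-bond acceptor that 4-methylphenyl lacks. The ring on the sulfonyl sulfur thus takes on a methoxy and a chlorine while compound 4 stays level with compounds 2 and 3, and only compound 1 stands apart, with a 2.2-fold higher number from compound 1 to compound 4 (0.35 log units; beyond the scatter) among these four. As far as these compounds go, whether an amine or a carboxylic acid on this ring would fall with compound 1 or with the other three stays open. No supporting measurement bears on why these ring exchanges give these numbers.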